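A few compounds are considered here, and "the series" means these few. Any claim that something is new, unique, unknown or untested is made for them only; others in the source may bear on it.

In a functional assay on THP-1 cells (Homo sapiens) for inhibition, read by ELISA, with stated times of 1 h and 18 h (on this read-out lower numbers stand for stronger inhibition and higher numbers for weaker inhibition), compound 3 (`NC(=O)[C@@H]1[C@H](Nc2nc(Nc3cccc(C(=O)N4CCCC4)c3)ncc2-c2ccncc2)[C@H]2C=C[C@@H]1C2`) gives 320 nM and lies within the scatter of compound 1 (`NC(=O)[C@@H]1[C@H](Nc2nc(Nc3ccc(C(=O)N4CCCC4)cc3)ncc2-c2cccnc2)[C@H]2C=C[C@@H]1C2`) at 230 nM while compound 2 (`NC(=O)[C@@H]1[C@H](Nc2nc(Nc3cccc(C(=O)N4CCCC4)c3)ncc2C2CC2)[C@H]2C=C[C@@H]1C2`) gives 90 nM as a smaller number. The change to compound 4 (`NC(=O)[C@@H]1[C@H](Nc2nc(Nc3cccc(C(=O)N4CCCC4)c3)ncc2-c2ccnc(F)c2)[C@H]2C=C[C@@H]1C2`) is fluoro in place of hydrogen on an aromatic carbon in the form of fluoro in place of hydrogen on an aromatic carbon next to the ring nitrogen, taking pyridin-4-yl to 2-fluoropyridin-4-yl. Among the compounds with values here, only one measured step touches this group: a 3.6-fold higher number from compound 2 to compound 3 (0.55 log units; beyond the scatter) with pyridin-4-yl in place of cyclopropyl. Within the data shown here, that modest step exchanges the whole group, and no measured compound carries a substituent on that ring, so no shift beyond the scatter is expected in this assay here. The expected step is a 1.3-fold lower number from compound 3 to compound 4 (0.11 log units; within the scatter) and stays within the scatter. For compound 4 the estimate is 250 nM with an expected range from 100 nM to 600 nM in this measurement.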

Compound 4, half-maximal inhibitory concentration: 100 nM
For compound 4 the middle estimate is 2.5-fold (0.40 log units) above the measured one; the range from low to high includes it.
By their numbers in this assay, from the lowest: compounds 2 and 4 (each within the scatter of the next); then compounds 1 and 3 (each within the scatter of the next).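

In this assay, within the data shown here, fluoro on the aromatic carbon next to the ring nitrogen gives a shift beyond the scatter (a 3.2-fold lower number from compound 3 to compound 4 (0.51 log units; beyond the scatter)), showing that this ring responds to a single substituent, which the earlier compounds, all without one there, could not show. The 2-fluoropyridin-4-yl and cyclopropyl groups cannot be told apart in this read-out (a 1.1-fold higher number from compound 2 to compound 4 (0.05 log units; within the scatter)). Nothing available accounts for the effect of fluoro.

From the compounds shown here alone, it remains open whether chloro, methyl, methoxy or an amine on that same carbon would give a similar step, and whether the step would hold with the other aniline arrangement of compound 1.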